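The source may hold more compounds than are shown below. What is called first, only, known or untested is meant among the compounds shown, and "the series" means these compounds.

Measured in a physicochemical assay for lipophilicity; on this read-out lower numbers stand for lower lipophilicity and higher numbers for higher lipophilicity:
- compound 1 `CCCCS(=O)(=O)c1ccc(O)c(C(=O)Nc2ccc(Br)cc2)c1` — 2.48
- compound 2 `CCCCCCCCS(=O)(=O)c1ccc(O)c(C(=O)Nc2ccc(C(F)(F)F)cc2)c1` — 5.26
- compound 3 `CCCCCCCCCCCCS(=O)(=O)c1ccc(O)c(C(=O)Nc2ccc(C(F)(F)F)cc2)c1` — 6.2

In this assay compound 3 stands highest of the three at 6.2, beyond the scatter from both other compounds. The next structure is compound 4 `CS(=O)(=O)c1ccc(O)c(C(=O)Nc2ccc(C(F)(F)F)cc2)c1`, and the change to it is hydrogen in place of undecyl on a saturated chain carbon bound to a sulfonyl sulfur.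

For the measured compounds named here, one measured step bears directly on this change: a number 0.94 log units higher from compound 2 to compound 3 (beyond the scatter), modest but beyond the scatter, with butyl in place of hydrogen on the chain. The new change removes far more of the chain and runs the opposite way, so a much larger fall is expected. Going by the values given here, compound 1 carries a butyl chain and differs elsewhere as well, so it offers no clean step, but its 2.48 suggests that the numbers keep falling at short chain lengths.

The expected change is a number 4.60 log units lower from compound 3 to compound 4 (beyond the scatter), a fall well beyond the scatter. Compound 4 is estimated at 1.6, with an expected range from 0.8 to 2.5.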

Compound 4, distribution coefficient: 1.48
Compound 4: the middle estimate sits 0.12 log units above what was measured; the range from low to high includes it.
By their numbers in this assay, from the lowest: compound 4; then compound 1; then compound 2; then compound 3.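

In this assay, the chain on the saturated carbon bound to a sulfonyl sulfur now has a reading at its short end, and hydrogen in place of undecyl gives a number 4.72 log units lower from compound 3 to compound 4 (beyond the scatter). Hydrogen in place of heptyl gives a number 3.78 log units lower from compound 2 to compound 4 (beyond the scatter), so among the three compounds sharing the trifluoromethyl-bearing core, most of the span lies on the short side of compound 2, well beyond a number 0.94 log units higher from compound 2 to compound 3 (beyond the scatter) at the long side. Nothing at hand accounts for the size of these steps.

On these data alone, how the numbers run at chain lengths between those of compound 4 and compound 2 remains open, as does whether a longer chain than that of compound 3 would continue the rise. A chain ending in an amine or a carboxylic acid at this place is also untested in the compounds shown.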